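A few compounds are considered here, and "the series" means these few. Any claim that something is new, unique, unknown or untested is made for them only; others in the source may bear on it.

Compound 1 `COc1ncnc2c1c(-c1ccoc1)cn2[C@@H]1O[C@H](CO)[C@@H](O)[C@H]1O` is the reference point of this small set. In a functional assay on HepG2 cells (Homo sapiens) for antiproliferative activity, read by XTT assay, with a stated time of 72 h (a higher number here means a weaker inhibitor, a lower number a stronger inhibitor), compound 1 gives 290 nM. Compound 2 `Cc1ncnc2c1c(-c1ccoc1)cn2[C@@H]1O[C@H](CO)[C@@H](O)[C@H]1O` carries methyl in place of methoxy on an aromatic carbon; in this assay compound 2 gives 5320 nM, and the step of an 18-fold higher number from compound 1 to compound 2 (1.26 log units; beyond the scatter). The two cores differ by thiophen-2-yl in place of furan-3-yl on an aromatic carbon, giving compound 3 `COc1ncnc2c1c(-c1cccs1)cn2[C@@H]1O[C@H](CO)[C@@H](O)[C@H]1O`, which in this assay gives 13900 nM, the step of a 48-fold higher number from compound 1 to compound 3 (1.68 log units; beyond the scatter). Compound 4 `Cc1ncnc2c1c(-c1cccs1)cn2[C@@H]1O[C@H](CO)[C@@H](O)[C@H]1O` has not been measured; it differs from compound 3 by methyl in place of methoxy on an aromatic carbon, the same change as between compound 1 and compound 2. The expected step is a 5.8-fold higher number from compound 3 to compound 4 (0.76 log units; beyond the scatter), resting on the step of an 18-fold higher number from compound 1 to compound 2 (1.26 log units; beyond the scatter) seen on the other core, though a number this high may only be reported as a limit. Compound 4 is therefore expected to give about 80000 nM, estimated between 20000 nM and 300000 nM.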

Compound 4, half-maximal inhibitory concentration: > 15000 nM
Compound 4: only a limit was reported; the forecaster's own chance of this, stated with the estimate: 40%; the middle value is on the limit's open side.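

In this assay compound 4 is reported only as a limit, > 15000 nM. Carried to the core of compound 3, methyl in place of methoxy gives an at least 1.0-fold higher number from compound 3 to compound 4 (0.03 log units; that floor lies within the scatter), so the data show only a floor and not whether the change has the same size on both cores: the same change on two cores in this assay, an 18-fold higher number (1.26 log units; beyond the scatter) from compound 1 to compound 2 and an at least 1.0-fold higher number (0.03 log units; that floor lies within the scatter) from compound 3 to compound 4; the limit leaves it open whether they differ Thiophen-2-yl in place of furan-3-yl, read on the methyl compounds, gives an at least 2.8-fold higher number from compound 2 to compound 4 (0.45 log units; beyond the scatter), which points the same way as on the methoxy compounds but does not fix the size of the step: the same change on two cores in this assay, a 48-fold higher number (1.68 log units; beyond the scatter) from compound 1 to compound 3 and an at least 2.8-fold higher number (0.45 log units; beyond the scatter) from compound 2 to compound 4; the limit leaves it open whether they differ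

The compounds shown leave open what an amine or a longer alkoxy chain would do in place of the methoxy. They also leave open how furan-2-yl or phenyl would compare with furan-3-yl on either core.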